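A few compounds are considered here, and "the series" means these few. Any claim that something is new, unique, unknown or untested is made for them only; others in the source may bear on it.

Measured so far in a functional assay on HT-29 cells (Homo sapiens) for cytotoxicity, read by MTT assay, with a stated time of 6 days; on this read-out higher numbers stand for an effect only at larger amounts of compound and lower numbers for an effect already at smaller amounts:
- compound 1 `COC(=O)c1c(-c2ccc(O)cc2)oc2ccccc2c1=O`: compound 1 gives > 25 ug/mL, which is a limit of the assay rather than a number.
- compound 2 `COC(=O)c1c(-c2ccc(O)cc2)oc2cc(OC)ccc2c1=O`: compound 2 gives 19.2 ug/mL.
- compound 3 `COc1ccc2c(=O)cc(-c3cc(OC)c(OC)c(OC)c3)oc2c1`: compound 3 gives > 25 ug/mL, again a limit of the assay.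

From compound 1 to compound 2 the change is methoxy in place of hydrogen on an aromatic carbon and the step made is an at least 1.3-fold lower number from compound 1 to compound 2 (0.11 log units; that floor lies within the scatter); its floor rests on (the limit of > 25 ug/mL in this assay, at which 2 of the 3 values shown sit). Compound 4 `COc1cc(-c2cc(=O)c3ccc(OC)c(OC)c3o2)cc(OC)c1OC` has not been measured; it arises from compound 3 by methoxy in place of hydrogen on an aromatic carbon. This is the same kind of change, not the same one: around the new group the surroundings differ, being ortho to a fused ring, ortho to a methoxy group and meta to a fused ring, rather than meta to a fused ring and para to a fused ring. The difference between the two cores is not broken down here. From compound 3 to compound 4 a step of about an at least 1.0-fold lower number from compound 3 to compound 4 (0.01 log units; that floor lies within the scatter) is expected, resting on the measured step of an at least 1.3-fold lower number from compound 1 to compound 2 (0.11 log units; that floor lies within the scatter) and on compound 3 giving only the limit > 25 ug/mL. For compound 4 the estimate is 24 ug/mL, between 9 ug/mL and 60 ug/mL.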

Compound 4, concentration for half-maximal effect: > 25 ug/mL
Compound 4 ended at the assay's limit (the forecaster's own chance of this, stated with the estimate: 60%); middle value at least 1.0-fold (0.01 log units) away from the limit.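

Among these compounds, compound 3 and compound 4 both end at a limit of the assay rather than a number, so no step between them can be read: the limit of > 25 ug/mL in this assay, at which 3 of the 4 values shown sit.

On these data alone, whether methoxy in place of hydrogen at this place alters the effect on these cells stays open.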